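From Phenyl to 3-Methylphenyl on a Shared Core

This account rests on a few compounds, and the source may have more. Where it says the series, first, only, none or still open, it means among the compounds named here.

Two compounds with a shared core and a phenylbutyl amide chain have been measured so far. In a functional assay on HOS-TE85 cells (Homo sapiens) for inhibition, read by CCK-8 assay, with a stated time of 72 h (on this read-out higher numbers stand for weaker inhibition and lower numbers for stronger inhibition), compound 1 `COc1ccc(OC)c(N2C(=O)CSC2c2cccc(C(=O)NCCCCc3ccccc3)c2)c1` gives > 1000 nM as its result, which is a limit of the assay and not a number. Within the data shown here, compound 2 `O=C(NCCCCc1ccccc1)c1cccc(C2SCC(=O)N2c2ccccc2)c1` gives 15.9 nM and so holds the only true number available. Phenyl in place of 2,5-dimethoxyphenyl on an amide-type nitrogen in a ring produced an at least 62-fold lower number from compound 1 to compound 2 (1.79 log units; beyond the scatter) and this large step is the only measured one that bears on the next change. Compound 3 `Cc1cccc(N2C(=O)CSC2c2cccc(C(=O)NCCCCc3ccccc3)c2)c1` has methyl in place of hydrogen on an aromatic carbon of that same phenyl, giving 3-methylphenyl. The one substituted ring measured so far, in compound 1, sits on the weak side of an at least 62-fold lower number from compound 1 to compound 2 (1.79 log units; beyond the scatter) and so a move towards a higher number is expected, though a much smaller one for this single methyl. The estimated change is a 2.5-fold higher number from compound 2 to compound 3 (0.40 log units; beyond the scatter) in this assay with a result beyond the scatter not assured. Compound 3 is expected at 40 nM (estimated range 10 nM to 250 nM).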

Compound 3, half-maximal inhibitory concentration: 93.2 nM
The estimate for compound 3 lay 2.3-fold (0.37 log units) below the measured number; measured number inside the range.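

In this assay, among these compounds, the single methyl on the phenyl ring, meta to a large group, gives a 5.9-fold higher number from compound 2 to compound 3 (0.77 log units; beyond the scatter), which is the first reading of one small group added to this ring on its own, and even that one carbon moves the number beyond the scatter. The ring of compound 3 nonetheless stays well clear of 2,5-dimethoxyphenyl, with an at least 10-fold lower number from compound 1 to compound 3 (1.03 log units; beyond the scatter), so a substituted ring on this nitrogen does not have to fall as far as the other substituted ring shown. Compound 1 remains a limit and not a number, so the full size of that step stays unknown: the limit of > 1000 nM in this assay, at which 1 of the 3 values shown sits.

The compounds shown leave open whether a fluorine, a chlorine or a single methoxy at this same place would follow the methyl, and whether a methyl elsewhere on the ring would give a step of similar size. They also leave open how far the phenyl result carries over to the rest of the structure, for instance with a shorter chain in place of the phenylbutyl amide chain.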